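Moving the fluorine on a second biaryl core

The source may hold more compounds than are shown below. What is called first, only, known or untested is meant among the compounds shown, and "the series" means these compounds.

In an assay on mitochondria (strain BALB/c) for inhibition of glycerol-3-phosphate acyltransferase 1, mitochondrial (Mus musculus), read by scintillation counting, with a stated time of 10 min (on this read-out lower numbers stand for stronger inhibition and higher numbers for weaker inhibition), three octanesulfonamide benzoic acids have been measured. Compound 1 `CCCCCCCCS(=O)(=O)Nc1cc(-c2ccccc2F)ccc1C(=O)O` gives 47200 nM. Compound 2 `CCCCCCCCS(=O)(=O)Nc1cc(-c2cccc(F)c2)ccc1C(=O)O` gives 32600 nM. Compound 3 `CCCCCCCCS(=O)(=O)Nc1ccc(-c2ccccc2F)cc1C(=O)O`, built on a different core, gives 34600 nM. The difference between the two cores is not broken down here. Within the first core, the change 3-fluorophenyl in place of 2-fluorophenyl on an aromatic carbon gave a 1.4-fold lower number from compound 1 to compound 2 (0.16 log units; within the scatter), so the two values sit within the usual scatter of each other and no order between them can be claimed. Compound 3 also lies within the scatter of both compound 1 and compound 2.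

Compound 4 `CCCCCCCCS(=O)(=O)Nc1ccc(-c2cccc(F)c2)cc1C(=O)O` has not yet been measured. It carries the change (3-fluorophenyl in place of 2-fluorophenyl on an aromatic carbon). The place is described differently in the two pairs: in the first core the change sits meta to a large group and para to a carboxy group, in the second core it sits meta to a carboxy group and para to a large group, so it is the same kind of change rather than the same change. Beside the measured step, the expected step is a 1.3-fold lower number from compound 3 to compound 4 (0.11 log units; within the scatter), resting only on the earlier pair. Because the earlier step was a 1.4-fold lower number from compound 1 to compound 2 (0.16 log units; within the scatter) and compound 3 gives 34600 nM, compound 4 is expected to give about 27000 nM. The estimate for compound 4 spans from 12000 nM to 60000 nM.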

Compound 4, half-maximal inhibitory concentration: 37600 nM
The estimate for compound 4 lay 1.4-fold (0.14 log units) below the measured number; the measured number falls inside the stated range.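

In this assay, putting 3-fluorophenyl in place of 2-fluorophenyl on the core of compound 3 gave a 1.1-fold higher number from compound 3 to compound 4 (0.04 log units; within the scatter), so no order can be claimed within this pair. Set beside the same change on the core of compound 1, the new step does not differ from the earlier one: the same change on two cores in this assay, a 1.4-fold lower number (0.16 log units; within the scatter) from compound 1 to compound 2 and a 1.1-fold higher number (0.04 log units; within the scatter) from compound 3 to compound 4, 1.6-fold (0.20 log units) apart, within the scatter of two such steps. This shows that on both cores the change leaves the number within the scatter, and nothing in these four compounds speaks against the same small outcome on either core, but it does not show that the change has a real effect that carries from one core to the other, as neither step can be told apart from repeat scatter and two such steps would agree whether or not a shared effect existed.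

The compounds shown leave open whether a substituent other than fluorine on the outer phenyl ring, such as chlorine or a methoxy group, would move the number beyond the scatter on either core. They also leave open how the two cores would compare if the octane chain gave way to a shorter or longer chain, or the carboxylic acid to an amide.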